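This account rests on a few compounds, and the source may have more. Where it says the series, first, only, none or still open, it means among the compounds named here.

Measured in a functional assay on MGC-803 cells (Homo sapiens) for cytotoxicity, read by MTT assay, with a stated time of 72 h; on this read-out lower numbers stand for stronger inhibition and higher numbers for weaker inhibition:
compound 1 `CCCCCCCCCCCCNc1nc(SCc2ccc(C(F)(F)F)cc2)nc2ccccc12`: > 50000 nM
compound 2 `FC(F)(F)c1ccc(CSc2nc(Nc3ccccc3)c3ccccc3n2)cc1`: 22200 nM
compound 3 `FC(F)(F)c1ccc(CSc2nc(Nc3cccc(C(F)(F)F)c3)c3ccccc3n2)cc1`: 15100 nM

In this assay compound 1 reaches only a limit, (the limit of > 50000 nM in this assay, at which 1 of the 3 values shown sits). For the measured compounds named here, compound 2 gives 22200 nM and compound 3 gives 15100 nM; the two numbers lie within the scatter of each other, and the only measured step, a 1.5-fold lower number from compound 2 to compound 3 (0.17 log units; within the scatter), is the one between them. Compound 3 thus stands with compound 2 as the pair of numbered values in the set, with compound 1 recorded as a limit.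

Compound 4 `COc1ccc(Nc2nc(SCc3ccc(C(F)(F)F)cc3)nc3ccccc23)c(OC)c1` is not yet measured. It differs from compound 3 as follows: 2,4-dimethoxyphenyl in place of 3-(trifluoromethyl)phenyl on a nitrogen on an aromatic ring. Going by the values given here, the one measured step concerns the same ring, since it adds trifluoromethyl at an aromatic carbon there, and it stayed within the scatter. Among the compounds with values here, no measured step covers the methoxy groups that enter. The change in compound 4 removes the trifluoromethyl ring and brings in the dimethoxy ring, so the expected step in this assay, a 1.2-fold higher number from compound 3 to compound 4 (0.08 log units; within the scatter), is not expected to exceed the scatter, with no direction favoured. For compound 4 the estimate in this assay is 18000 nM, with a range from 6000 nM to 50000 nM.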

Compound 4, half-maximal inhibitory concentration: > 50000 nM
Compound 4 gave a limit, no number; the forecaster's own chance of this, stated with the estimate: 20%; middle value at least 2.7-fold (0.44 log units) from the limit.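

In this assay, the aryl group on the nitrogen now gives steps beyond the scatter: 2,4-dimethoxyphenyl in place of 3-(trifluoromethyl)phenyl gives an at least 3.3-fold higher number from compound 3 to compound 4 (0.51 log units; beyond the scatter), and 2,4-dimethoxyphenyl in place of phenyl gives an at least 2.2-fold higher number from compound 2 to compound 4 (0.35 log units; beyond the scatter). The only earlier step on this ring, the addition of trifluoromethyl, stayed within the scatter, so the change to 2,4-dimethoxyphenyl is the first change on this ring shown to move the read-out, and it moves it towards weaker inhibition. Compound 4 gives a limit and not a number, so both steps are lower bounds on the true size, and compound 4 now shares that limit with compound 1: the limit of > 50000 nM in this assay, at which 2 of the 4 values shown sit.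

The compounds shown leave open whether a single methoxy group, at either of the two places it holds in 2,4-dimethoxyphenyl, would be enough for such a step, or whether both are needed. They also leave open whether the step belongs to methoxy itself or would also appear with a hydroxyl group, an amine or a carboxylic acid on this ring.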